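A saturated ring in place of pyridin-3-yl

The compounds below may be only part of what the source reports. "The series", "measured", "known", "first", "only" and "open" are said of these compounds alone.

Compound 1, `O=C(c1cccnc1)N1CCC(NS(=O)(=O)c2cc(S(=O)(=O)c3ccccc3)ccc2C(F)(F)F)CC1`: 0.0333 h
Compound 2, `O=C(c1ccc(Cl)nc1)N1CCC(NS(=O)(=O)c2cc(S(=O)(=O)c3ccccc3)ccc2C(F)(F)F)CC1`: 0.15 h
Compound 3, `O=C(C1CCNCC1)N1CCC(NS(=O)(=O)c2cc(S(=O)(=O)c3ccccc3)ccc2C(F)(F)F)CC1`: > 0.5 h, a limit of the assay rather than a number

In an in vitro ADME assay on microsomes from liver (Rattus norvegicus) for metabolic stability, tested at 1 uM (on this read-out lower numbers stand for a shorter-lived compound and higher numbers for a longer-lived compound), compound 1 stands lowest of the two numbers measured; its nearest neighbour is compound 2, reached by a chloro in place of hydrogen on an aromatic carbon, a change that gave a 4.5-fold higher number from compound 1 to compound 2 (0.65 log units; beyond the scatter). Compound 3 sits at the limit of > 0.5 h in this assay, at which 1 of the 3 values shown sits, so for it only a limit is known. The move from compound 1 to compound 3, piperidin-4-yl in place of pyridin-3-yl on a carbonyl carbon, gave an at least 15-fold higher number from compound 1 to compound 3 (1.17 log units; beyond the scatter).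

Compound 4, `O=C([C@H]1CCNC1)N1CCC(NS(=O)(=O)c2cc(S(=O)(=O)c3ccccc3)ccc2C(F)(F)F)CC1`, has not yet been measured. It differs from compound 1 in one place: pyrrolidin-3-yl in place of pyridin-3-yl on a carbonyl carbon. Among the compounds with values here, this is the change closest in kind to the one from compound 1 to compound 3, a five-membered saturated ring with one hetero atom entering where a six-membered one did there. Within the data shown here, that step is therefore the one expected to guide the outcome, with the step to compound 2 as a smaller second reference.

Compound 4 is thus expected to show a large rise in this assay, a 12-fold higher number from compound 1 to compound 4 (1.08 log units; beyond the scatter), with the estimate 0.4 h in a range from 0.12 h to 0.6 h; there is a real chance that the assay reports only a limit.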

Compound 4, half-life: > 0.5 h
Compound 4 gave a limit, no number; the forecaster's own chance of this, stated with the estimate: 40%; at least 1.2-fold (0.09 log units) between middle value and limit.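

In this assay, compound 4 gives only a limit and not a number, the same limit that compound 3 reached: the limit of > 0.5 h in this assay, at which 2 of the 4 values shown sit. The rise seen with the piperidin-4-yl group is therefore not tied to that one ring, since the smaller, five-membered non-aromatic pyrrolidin-3-yl ring on the same carbonyl carbon gives an at least 15-fold higher number from compound 1 to compound 4 (1.17 log units; beyond the scatter), and, set against the 6-chloropyridin-3-yl group, it gives an at least 3.3-fold higher number from compound 2 to compound 4 (0.52 log units; beyond the scatter). Among the compounds shown, the two with a non-aromatic ring on this carbonyl carbon, compound 3 and compound 4, both sit at the limit, while the two with a pyridine ring, compound 1 and compound 2, lie lower, and no compound shown goes against this split.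

The two limits leave the step between compound 3 and compound 4 unreadable, so the two ring sizes cannot be ranked against each other. Going by these compounds, it also remains open whether the ring nitrogen matters or the loss of the aromatic ring is enough, a question that a cyclopentyl group on the same carbonyl carbon could help to answer.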